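Aryl variation on the shared core: chloro to methyl

The compounds below may be only part of what the source reports. "The series", "measured", "known", "first", "only" and "open" are said of these compounds alone.

Three compounds of the series have a number in an assay on CHO cells for displacement of a labelled ligand from adenosine receptor A1 (Homo sapiens), read by scintillation counting, with a stated time of 3 h; on this read-out lower numbers stand for stronger inhibition and higher numbers for weaker inhibition. Compound 1 `Cn1c(-c2cccc(Cl)c2)nc2c(NC3CCCC3)ncnc21` gives 6.5 nM and stands lowest of the three. Compound 2 `CCn1c(-c2ccccc2)nc2c(NC3CCCCC3)ncnc21` gives 10 nM, within the scatter of compound 1, so the two cannot be ordered. Going by the values given here, compound 3 `Cn1c(-c2ccc(C(=O)O)cc2)nc2c(NC3CCCC3)ncnc21` gives 54000 nM, far beyond the scatter from compound 1; the two differ in more than one place, so only the pair of values is noted. Among the compounds with values here, no step between measured compounds differing in one place is available.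

Compound 4 `Cc1ccccc1-c1nc2c(NC3CCCC3)ncnc2n1C` has not yet been measured in this assay. It differs from compound 1 as follows: 2-methylphenyl in place of 3-chlorophenyl on an aromatic carbon. The substituent leaving and the one entering are of the same size, and neither carries a donor or an acceptor. Within the data shown here, the data give no step of this kind to lean on, so any expectation is loose. Compound 4 is expected to stay nearer compound 1 than compound 3, but a moderate move toward a higher number, beyond the scatter, is expected: a 4.6-fold higher number from compound 1 to compound 4 (0.66 log units; beyond the scatter). The estimate for compound 4 in this assay is 30 nM, with a range from 5 nM to 200 nM.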

Compound 4, inhibition constant: 55 nM
Estimate against measurement, compound 4: 1.8-fold (0.26 log units) below; the range from low to high includes it.
By their numbers in this assay, from the lowest: compounds 1 and 2 (each within the scatter of the next); then compound 4; then compound 3.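

In this assay, going by these compounds alone, the only single-place step so far is 2-methylphenyl in place of 3-chlorophenyl on the aromatic carbon between two ring nitrogen atoms: an 8.5-fold higher number from compound 1 to compound 4 (0.93 log units; beyond the scatter), a modest step beyond the scatter. This position therefore responds to an exchange that leaves the count of heavy atoms, the carbon-only aromatic ring and the zero counts of donors and acceptors unchanged, so these counts alone do not fix the number here. No measurement at hand accounts for the step.

The exchange alters both the substituent and where it sits on the phenyl ring, and the compounds shown cannot separate the two. A 3-methylphenyl or a 2-chlorophenyl at this carbon would address that, and a 3-aminophenyl would show how an amine is received there.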